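The source may hold more compounds than are shown below. What is called first, only, known or untested is meant among the compounds shown, and "the series" means these compounds.

Measured compounds:
- compound 1 `CC(C)c1ccccc1NC(=O)N[C@H](C)c1ccccc1`; in an ADME assay on the whole organism with Oryza sativa as the target, tested at 0.1 uM (on this read-out lower numbers stand for a stronger effect and higher numbers for a weaker effect at the one concentration tested), compound 1 gives 103%
- compound 2 `COc1ccccc1NC(=O)N[C@H](C)c1ccccc1`; in this assay compound 2 gives 100%

Compound 2 has the lower of the two numbers in this assay, but its nearest neighbour is compound 1, and the step of a number 3 percentage points lower from compound 1 to compound 2 (within the scatter) is within the scatter, so the two compounds cannot be told apart on these numbers.

Compound 3 `C[C@@H](NC(=O)Nc1ccccc1Cl)c1ccccc1` is not yet measured. Its change from compound 2 is chloro in place of methoxy on an aromatic carbon. Among the compounds with values here, only one measured step bears on this: the swap of one small group for another at the same aromatic carbon, a number 3 percentage points lower from compound 1 to compound 2 (within the scatter), which was within the scatter. On that basis the step of no change at the digits printed from compound 2 to compound 3 (within the scatter) is expected to be small, with no direction beyond the scatter. Compound 3 is therefore estimated to give 100% in this assay, in a range from 88% to 110%.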

Compound 3, a percentage reported as activity, at one concentration (the size of the read-out at that concentration, not a potency): 101%
Beside the measured number, compound 3's estimate is 1 percentage points below it; measured number inside the range.
By their numbers in this assay, from the lowest: compounds 2, 3 and 1 (each within the scatter of the next).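

In this assay, chloro in place of methoxy on an aromatic carbon ortho to a large group gives a number 1 percentage points higher from compound 2 to compound 3 (within the scatter) and chloro in place of isopropyl at that carbon gives a number 2 percentage points lower from compound 1 to compound 3 (within the scatter) on the same read-out. This adds a third group at this position, one with a single chlorine atom and no hydrogen-bond acceptor, and isopropyl, methoxy and chloro still cannot be told apart on these numbers. Nothing measured here bears on why these compounds read alike.

The compounds shown leave open whether a quite different group at this position, such as an amine or a carboxylic acid, would give a step beyond the scatter. They also leave open whether chloro would read the same on another carbon of this ring, or at another concentration.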